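The compounds below may be only part of what the source reports. "The series", "measured", "known", "first", "only" and "open" are said of these compounds alone.

Measured compounds

Compound 1 `COc1ccc2[nH]c(-c3cc(OC)c(OC)c(OC)c3)cc2c1` — in a functional assay on MCF7 cells (Homo sapiens) for cytotoxicity, read by MTT assay, with a stated time of 24 h (on this read-out higher numbers stand for weaker inhibition and lower numbers for stronger inhibition), compound 1 gives > 30000 nM, which is a limit of the assay, not a number.
Compound 2 `COc1ccc2c(c1)cc(-c1cc(OC)c(OC)c(OC)c1)n2Cc1ccc(OCc2ccccc2)cc1` — in this assay compound 2 gives > 30000 nM, likewise a limit.
Compound 3 `COc1ccc2c(c1)cc(-c1cc(OC)c(OC)c(OC)c1)n2Cc1ccc(O)cc1` — in this assay compound 3 gives > 30000 nM, again a limit.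

Compound 3 therefore stands only at a limit in this assay; no number places it against its neighbours. The two measured steps that lead to it, a step that the two limits leave unreadable from compound 1 to compound 3 and a step that the two limits leave unreadable from compound 2 to compound 3, both run between limits and their sizes cannot be read. All three values sit at the limit of > 30000 nM in this assay, at which 3 of the 3 values shown sit.

The next compound, compound 4 `COc1ccc(Cn2c(-c3cc(OC)c(OC)c(OC)c3)cc3cc(OC)ccc32)cc1`, differs from compound 3 by methyl in place of hydrogen on an oxygen on an aromatic ring. Among the compounds with values here, compound 2, which carries a larger group on the same oxygen, and compound 3, which carries hydrogen there, both sit at the limit, so no measured step gives the expected size or direction of the change in this assay; a further limit is the most likely outcome. Compound 4 is therefore expected at 60000 nM, with a range from 20000 nM to 300000 nM, the estimated step from compound 3 being a step that the limit leaves unreadable from compound 3 to compound 4, most probably reported only as a limit.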

Compound 4, half-maximal inhibitory concentration: > 30000 nM
Compound 4: a limit, no number; the forecaster's own chance of this, stated with the estimate: 85%; the middle value is on the limit's open side.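

In this assay compound 4 gives > 30000 nM, which is a limit and not a number. No step to compound 4 from compound 1, compound 2 or compound 3 can be read: the limit of > 30000 nM in this assay, at which 4 of the 4 values shown sit.

The compounds shown leave open which change to the shared core, if any, gives a readable value in this assay.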